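From Trifluoromethyl to Fluoro on the Aromatic Carbon

The source may report more compounds than this note shows. Statements on the series, on what has been measured and on what is new or still open speak of the compounds shown alone.

Of the compounds shown here, three sharing one core have been tested in a functional assay (MiaPaCa cells, Homo sapiens) for inhibition, read by sulforhodamine B assay, with a stated time of 48 h; on this read-out lower numbers stand for stronger inhibition of growth and higher numbers for weaker inhibition of growth. Compound 1 `O=C(CCN1C(=O)CSc2ccccc21)N1CCN(c2ccc([N+](=O)[O-])cc2)CC1` gives 68100 nM, and compound 3 `O=C(CCN1C(=O)CSc2ccccc21)N1CCC(Cc2ccccc2)CC1` gives 56800 nM. Compound 2 `O=C(CCN1C(=O)CSc2ccccc21)N1CCN(c2ccc(C(F)(F)F)cc2)CC1` reaches only a limit, > 100000 nM, in this assay. Compound 2 thus stands at the limit of > 100000 nM in this assay, at which 1 of the 3 values shown sits, rather than at a number. For the measured compounds named here, the only measured step touching this part of the structure, an at least 1.4-fold higher number from compound 1 to compound 2 (0.16 log units; that floor lies within the scatter), is too small for any direction to be read from it. Compound 4 `O=C(CCN1C(=O)CSc2ccccc21)N1CCN(c2ccc(F)cc2)CC1` differs from compound 2 by fluoro in place of trifluoromethyl on an aromatic carbon. Going by the values given here, since no measured step covers the exchange of trifluoromethyl for fluoro, and since the single step into the trifluoromethyl compound lies within the scatter, the step of an at least 1.2-fold lower number from compound 2 to compound 4 (0.09 log units; that floor lies within the scatter) is expected to be modest and could fall either way. Compound 4 is expected to give about 80000 nM in this assay, within a range from 35000 nM to 200000 nM, with a fair chance that only a limit is again reported.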

Compound 4, concentration for 50% growth inhibition: > 100000 nM
Compound 4 gave a limit, no number; the forecaster's own chance of this, stated with the estimate: 40%; at least 1.2-fold (0.09 log units) between middle value and limit.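

In this assay, compound 4 ends at a limit of the assay, as compound 2 does, so the step from 4-(trifluoromethyl)phenyl to 4-fluorophenyl cannot be read in size or direction. For the compounds shown here, the one readable new step is an at least 1.4-fold higher number from compound 1 to compound 4 (0.16 log units; that floor lies within the scatter), so the exchange of nitro for fluoro gives no direction either. What the result adds is that the limit now appears with two different groups on this aromatic carbon, not with trifluoromethyl alone: the limit of > 100000 nM in this assay, at which 2 of the 4 values shown sit.

Left open is whether an amine or a carboxylic acid on this aromatic carbon, para to a large group, would give a number rather than a limit in this assay. Equally open, as far as these compounds go, is whether a methoxy group or a longer chain at that place would stand apart from compound 1 by more than the scatter.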